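The compounds below may be only part of what the source reports. "The series", "measured", "known", "first", "only" and "open" are said of these compounds alone.

Measured compounds in a functional assay on PC-3 cells (Homo sapiens) for inhibition; on this read-out higher numbers stand for weaker inhibition and lower numbers for stronger inhibition:
compound 1, `COc1cc2nc(N3CCN(S(=O)(=O)c4ccc(C)cc4)CC3)nc(N)c2cc1OC`: 30000 nM
compound 2, `COc1ccc(S(=O)(=O)N2CCN(c3nc(N)c4cc(OC)c(OC)cc4n3)CC2)cc1`: 39000 nM
compound 3, `COc1cc2nc(N3CCN(S(=O)(=O)c4ccc(S(C)(=O)=O)cc4)CC3)nc(N)c2cc1OC`: 17000 nM

Compound 3 is separated from compound 2 by a 2.3-fold lower number from compound 2 to compound 3 (0.36 log units; beyond the scatter). Against compound 1 the gap is only a 1.8-fold lower number from compound 1 to compound 3 (0.25 log units; within the scatter), so the two cannot be told apart on these numbers. Compound 1 and compound 2 likewise sit within the scatter of each other, a 1.3-fold higher number from compound 1 to compound 2 (0.11 log units; within the scatter). All three exchanges concern the same aromatic carbon of the arylsulfonyl group and none of them moved the read-out far.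

Compound 4, `CCCCc1ccc(-c2ccc(S(=O)(=O)N3CCN(c4nc(N)c5cc(OC)c(OC)cc5n4)CC3)cc2)cc1`, continues at that carbon: 4-butylphenyl in place of methylsulfonyl on an aromatic carbon. Among the compounds with values here, no measured step introduces a second aromatic ring, so the three steps bear on this one only in showing that exchanges at this position have so far produced small shifts. On that basis the step of a 1.2-fold higher number from compound 3 to compound 4 (0.07 log units; within the scatter) is expected to stay near the scatter, with no clear direction. For compound 4 the estimate in this assay is 20000 nM, with a range from 5000 nM to 70000 nM, kept wide since the new group is unlike any measured one.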

Compound 4, half-maximal inhibitory concentration: 3400 nM
Beside the measured number, compound 4's estimate is 5.9-fold (0.77 log units) above it, and the stated range ends above it.
By their numbers in this assay, from the lowest: compound 4; then compounds 3, 1 and 2 (each within the scatter of the next, the first and the last beyond it).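

In this assay, this aromatic carbon tolerates a much larger substituent and responds to it: 4-butylphenyl gives a 5.0-fold lower number from compound 3 to compound 4 (0.70 log units; beyond the scatter) and exceeds every earlier step at this position. The same exchange gives an 8.8-fold lower number from compound 1 to compound 4 (0.95 log units; beyond the scatter) as well as an 11-fold lower number from compound 2 to compound 4 (1.06 log units; beyond the scatter) on the read-out, making compound 4 the strongest inhibitor of the four, and the earlier differences among methyl, methoxy and methylsulfonyl look small by comparison. No accompanying measurement explains the shift.

Because the entering group combines an aromatic ring with a butyl chain, the compounds shown cannot separate the contribution of either part. A plain phenyl group would address that question, while a longer chain or an amine at the end of the new ring would show how far the trend extends.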